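Methoxy to hydroxy change, two parallel pairs

A few compounds are considered here, and "the series" means these few. Any claim that something is new, unique, unknown or untested is made for them only; others in the source may bear on it.

Compound 1, `COc1cc(-c2nn(-c3cccc(NC(=O)Nc4cc(C(F)(F)F)cc(C(F)(F)F)c4)c3)cc2-c2ccncc2)ccc1Cl`: 890 nM in a functional assay on MDA-MB-435 cells (Homo sapiens) for inhibition, read by sulforhodamine B assay, with a stated time of 48 h; on this read-out lower numbers stand for stronger inhibition and higher numbers for weaker inhibition
Compound 2, `O=C(Nc1cccc(-n2cc(-c3ccncc3)c(-c3ccc(Cl)c(O)c3)n2)c1)Nc1cc(C(F)(F)F)cc(C(F)(F)F)c1`: 910 nM in this assay
Compound 3, `COc1cc(-c2nn(-c3cccc(NC(=O)Nc4ccc(Cl)c(C(F)(F)F)c4)c3)cc2-c2ccncc2)ccc1Cl`: 680 nM in this assay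

From compound 1 to compound 2 the change is hydrogen in place of methyl on an oxygen on an aromatic ring; the step in this assay is a 1.0-fold higher number from compound 1 to compound 2 (0.01 log units; within the scatter). Compound 4, `O=C(Nc1cccc(-n2cc(-c3ccncc3)c(-c3ccc(Cl)c(O)c3)n2)c1)Nc1ccc(Cl)c(C(F)(F)F)c1`, is not yet measured and differs from compound 3 by hydrogen in place of methyl on an oxygen on an aromatic ring, the same change at the same place. The difference between the cores of compound 1 and compound 3 is not broken down here; their values lie within the scatter of each other, as do those of compound 2 and compound 3. Compound 4 is expected to show a step of a 1.0-fold higher number from compound 3 to compound 4 (0.01 log units; within the scatter) in this assay because the same change gave a 1.0-fold higher number from compound 1 to compound 2 (0.01 log units; within the scatter). The estimate for compound 4 in this assay is 700 nM, expected to fall between 350 nM and 1400 nM.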

Compound 4, half-maximal inhibitory concentration: 660 nM
Beside the measured number, compound 4's estimate is 1.1-fold (0.03 log units) above it, and the stated range covers the measured number.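

On the core of compound 3, methoxy to hydroxy gives a 1.0-fold lower number from compound 3 to compound 4 (0.01 log units; within the scatter) in this assay. Set beside the earlier pair, the change reads the same on both cores: the same change on two cores in this assay, a 1.0-fold higher number (0.01 log units; within the scatter) from compound 1 to compound 2 and a 1.0-fold lower number (0.01 log units; within the scatter) from compound 3 to compound 4, 1.1-fold (0.02 log units) apart, within the scatter of two such steps. This holds only for these two pairs in one cell assay; it does not show the same result on other cores or in other assays, and a step within the scatter gives no measurable size to carry over.

Still open, on these data alone, is whether other groups on this oxygen, such as an ethyl group or a longer chain, would give a step beyond the scatter. The same question stands for an amine or a carboxylic acid in place of the hydroxy.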